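The compounds below may be only part of what the source reports. "The series", "measured", "known", "first", "only" and "open" are said of these compounds alone.

Of the compounds shown here, two sharing one core have been measured in a functional assay on A549 cells (Homo sapiens) for antiproliferative activity, read by MTT assay, with a stated time of 24 h; on this read-out lower numbers stand for stronger inhibition and higher numbers for weaker inhibition. Compound 1, `COc1cc(-c2cc(C(=O)/C=C/c3ccc(Cl)cc3)nc3cc(-c4ccccc4)nn23)cc(OC)c1OC`, carries a 3,4,5-trimethoxyphenyl group and a chloro-substituted chalcone arm; in this assay compound 1 gives 23800 nM. Compound 2, `COc1ccc(-c2cc(C(=O)/C=C/c3ccc(C)cc3)nc3cc(-c4ccccc4)nn23)cc1OC`, carries instead a 3,4-dimethoxyphenyl group and a methyl-substituted chalcone arm, and in this assay compound 2 gives 22200 nM. Compound 2 thus holds the lower of the two numbers, but its distance to compound 1 lies within the usual scatter, so the two cannot be told apart on these data.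

Compound 3, `COc1ccc(-c2cc(/C=C/C(=O)c3ccccc3)nc3cc(-c4ccccc4)nn23)cc1OC`, is the next member to be examined. It differs from compound 2 in one place: 2-benzoylethenyl in place of (2-(4-methylphenyl)ethenyl)carbonyl on an aromatic carbon. In effect the carbonyl and the double bond trade ends of the arm, and the ring at its far end loses its methyl group. Among the compounds with values here, with no measured pair reporting such a change, the expectation must rest on the weak and nearly equal activity of compounds 1 and 2. The step of a 1.3-fold higher number from compound 2 to compound 3 (0.10 log units; within the scatter) is therefore expected to be small and of uncertain direction. Compound 3 is estimated to give 28000 nM, with a plausible range from 10000 nM to 80000 nM.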

Compound 3, half-maximal inhibitory concentration: 10700 nM
The estimate for compound 3 lay 2.6-fold (0.42 log units) above the measured number; the measured number falls inside the stated range.
By their numbers in this assay, from the lowest: compound 3; then compounds 2 and 1 (each within the scatter of the next).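

The change at this position, on the aromatic carbon next to the ring nitrogen, gives a 2.1-fold lower number from compound 2 to compound 3 (0.32 log units; beyond the scatter) in this assay, and this is the first step among these compounds that can be read as beyond the scatter. It shows that the arm at this place can alter the antiproliferative number, which the near-equal values of the two earlier compounds could not show, since those compounds differ in more than one place and share the same arm orientation. The replacement is a single change of substituent, yet it both exchanges the order of the carbonyl and ethenyl units and removes the methyl group from the terminal ring, and no measurement here explains the gain or assigns it to either feature.

The compounds shown leave open whether the 2-benzoylethenyl arm would keep this number with a methyl or chloro group restored on its terminal ring, or with the 3,4,5-trimethoxyphenyl group in place of the 3,4-dimethoxyphenyl group. They also leave open how this position would respond to an arm ending in an amine or a carboxylic acid, or to a saturated chain in place of the ethenyl link.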